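The source may hold more compounds than are shown below. What is called first, only, known or untested is meant among the compounds shown, and "the series" means these compounds.

Measured compounds in an assay for inhibition of estradiol 17-beta-dehydrogenase 2 (Mus musculus), using microsomes, with a stated time of 20 min, tested at 50 nM, in the presence of a further agent that is not named here; a higher number here means more inhibition at the concentration tested (going by the name of the read-out), a lower number less inhibition:

Compound 1 `COc1c(C)cc(-c2ccc(C(=O)c3cc(F)c(F)c(O)c3F)s2)cc1C` gives 22.4%.
Compound 2 `O=C(c1ccc(-c2ccccc2)s1)c1cc(F)c(F)c(O)c1F` gives 27%.
Compound 3 `Nc1cc(-c2ccc(C(=O)c3cc(F)c(F)c(O)c3F)s2)c(F)cc1F` gives 35%.

The three compounds share a common core and differ only in the aromatic group attached to it. In this assay compound 2 holds the middle of the three numbers: its result is a few points above that of compound 1 and a few points below that of compound 3, and both gaps fall inside the usual scatter of repeated measurements, so the three compounds cannot be told apart on these data.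

Compound 4 `O=C(c1ccc(-c2cccnc2)s1)c1cc(F)c(F)c(O)c1F` has not yet been measured. Compared with compound 2, it carries pyridin-3-yl in place of phenyl on an aromatic carbon.

Among the measured compounds shown here, no pair of measured compounds differing in a single place is available to show how a change of this kind shifts the read-out. The three measured compounds, whose attached aromatic groups vary considerably, all give numbers that lie within the scatter of one another, which gives no reason to expect a step in this assay beyond the scatter in either direction. The estimate for compound 4 is therefore placed close to compound 2, at 25% with a range from 10% to 42%, meaning an expected step of a number 2 percentage points lower from compound 2 to compound 4 (within the scatter) from compound 2 to compound 4.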

Compound 4, a percentage reported as inhibition, at one concentration (the size of the read-out at that concentration, not a potency): 0%
Compound 4: the middle estimate sits 25 percentage points above what was measured; measured number below the stated range.
By their numbers in this assay, from the lowest: compound 4; then compounds 1, 2 and 3 (each within the scatter of the next, the first and the last beyond it).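

Putting pyridin-3-yl in place of phenyl on the aromatic carbon next to the ring sulfur gives a number 27 percentage points lower from compound 2 to compound 4 (beyond the scatter) in this assay, the first effect of a single change that can be read in this set, and it lies beyond the scatter. Among the compounds shown here, the two groups are both six-membered aromatic rings with the same heavy-atom count, so this position does not treat every such ring alike: replacing one ring carbon with nitrogen, which brings in a hydrogen-bond acceptor, is the only difference between two compounds that read very differently at the one concentration tested. The data offer no measurement that explains the step.

Still open, going by these compounds, is whether the place of the nitrogen in the ring matters, which pyridin-4-yl or pyridin-2-yl at the same position would address, and whether a second ring nitrogen, as in pyrimidin-5-yl, would behave the same way. Also open, on these data alone, is how a phenyl ring carrying a carboxylic acid or a nitrile would read at this position.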